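Solubility After Trimming an Amide Substituent

The source may report more compounds than this note shows. Statements on the series, on what has been measured and on what is new or still open speak of the compounds shown alone.

Compound 1 `CNC(=O)c1cc(C(=O)NC2CC2)cc2c1OC[C@H]2c1cccc(F)c1`: >= 175 ug/mL (a limit)
Compound 2 `CCC(=O)N1C[C@@H]2[C@H](C1)[C@H]2NC(=O)c1cc(C(=O)NC)c2c(c1)[C@H](c1ccccc1)CO2`: >= 163 ug/mL (a limit)
Compound 3 `CNC(=O)c1cc(C(=O)NCCC[C@H]2OC[C@H](N)CO2)cc2c1O[C@H](CF)[C@H]2c1ccccc1`: 174 ug/mL

All three compounds were measured in a physicochemical assay for solubility; a lower number here means a less soluble compound, a higher number a more soluble compound. Compound 2 has no exact number there: compound 2 gives >= 163 ug/mL, which is a limit of the assay. Compound 1 is also reported only as a limit, at >= 175 ug/mL. Compound 3 is the only one of the three with an exact number, at 174 ug/mL.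

Compound 4 `CNC(=O)c1cc(C(=O)N[C@H]2C[C@@H]2C)cc2c1OC[C@H]2c1ccccc1` has not yet been measured in this assay. It differs from compound 2 in one place, on an amide-type nitrogen: a group of 4 heavy atoms (4 carbon; one three-membered non-aromatic ring of carbon only) in place of a group of 10 heavy atoms (8 carbon, 1 nitrogen, 1 oxygen; one three-membered non-aromatic ring of carbon only, one five-membered non-aromatic ring with 1 hetero atom), on an amide-type nitrogen. The 2-methylcyclopropyl group of compound 4 is much the smaller of the two groups. For the measured compounds named here, no pair of measured compounds shows a change of this kind, so the expectation has little direct support.

It rests first on compound 3, which gives 174 ug/mL. It also rests on compound 1, whose limit is >= 175 ug/mL. No step beyond the scatter is expected, in either direction, and the estimated step is an at least 1.0-fold lower number from compound 2 to compound 4 (0.03 log units; that floor lies within the scatter). For compound 4 the expected value is 150 ug/mL, with an estimated range from 80 ug/mL to 220 ug/mL.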

Compound 4, solubility: >= 76 ug/mL
Compound 4 gave a limit, no number (the forecaster's own chance of this, stated with the estimate: 45%); the middle value lies beyond the limit too.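

In this assay, compound 4 is reported only as a limit, >= 76 ug/mL. For the compounds shown here, compound 2 is likewise reported only as a limit, >= 163 ug/mL, so no step between compound 2 and compound 4 can be read. The compounds shown leave open whether the 2-methylcyclopropyl group on the amide-type nitrogen changes the read-out at all.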